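Amide-substituent variation on the shared core

This account rests on a few compounds, and the source may have more. Where it says the series, first, only, none or still open, it means among the compounds named here.

Three compounds share the core of compound 1, `CCCN(CCC)c1nc(N2CCN(C(=O)c3ccco3)[C@@H]3CCCC[C@@H]32)nc2cc(OC)c(OC)cc12`, and differ at the amide side of the fused ring system. In an assay on CHO cells for displacement of a labelled ligand from Alpha-1B adrenergic receptor (Homo sapiens), with a stated time of 30 min (a lower number here means a stronger inhibitor, a higher number a weaker inhibitor), compound 1 gives 0.129 nM. Compound 2, `COc1cc2nc(N3CCN(C(C)=O)[C@@H]4CCCC[C@@H]43)nc(N)c2cc1OC`, gives 0.741 nM in this assay. Compound 3, `CCCCCC(=O)N1CCN(c2nc(N)c3cc(OC)c(OC)cc3n2)[C@@H]2CCCC[C@@H]21`, gives 0.912 nM in this assay, the highest of the three numbers; its gap to compound 2 lies within the scatter, whereas compound 1 sits clearly lower, beyond the scatter.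

The next member, compound 4, `COc1cc2nc(N3CCN(C(=O)C(C)(C)C)[C@H]4CCCC[C@H]43)nc(N)c2cc1OC`, is not yet measured. Its change from compound 3 is tert-butyl in place of pentyl on a carbonyl carbon. Among the measured compounds shown here, no step between measured compounds isolates this kind of change; the nearest comparison is that compound 2 with its acetyl group and compound 3 with its pentylcarbonyl give numbers within the scatter of each other, so a change in chain shape here has not moved this assay. The expected step from compound 3 to compound 4, a 1.6-fold higher number from compound 3 to compound 4 (0.22 log units; within the scatter), is therefore no movement beyond the scatter. Compound 4 is estimated at 1.5 nM in this assay, with a range from 0.4 nM to 6 nM.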

Compound 4, inhibition constant: 0.776 nM
Beside the measured number, compound 4's estimate is 1.9-fold (0.29 log units) above it, within the range that was stated.
By their numbers in this assay, from the lowest: compound 1; then compounds 2, 4 and 3 (each within the scatter of the next).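

Among the compounds shown here, this is the first direct step at this position: in this assay, tert-butyl in place of pentyl on a carbonyl carbon gives a 1.2-fold lower number from compound 3 to compound 4 (0.07 log units; within the scatter). A change from the straight pentyl chain to tert-butyl, with one heavy atom fewer, therefore leaves this assay without movement beyond the scatter, and compound 4 falls in with compounds 2 and 3 rather than opening a gap between them. No supporting data bear on why this position tolerates the change.

From the compounds shown here alone, it remains open whether the flat response holds for groups of a different kind on this carbonyl carbon, such as a primary amine, a carboxylic acid or a much longer chain. A phenyl ring at this place would also test whether a ring changes the number on the shared core.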